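The source may report more compounds than this note shows. Statements on the series, on what has been measured and on what is new or still open speak of the compounds shown alone.

Measured so far in an assay on isolated protein for displacement of a labelled ligand from D(1B) dopamine receptor (Homo sapiens); a higher number here means a weaker inhibitor, a lower number a stronger inhibitor:
compound 1 `C=CCN1CCc2cc(OC)c(O)cc2C(c2ccccc2Br)C1` with 501 nM
compound 2 `C=CCN1CCc2cc(O)c(O)cc2C(c2ccccc2Br)C1` with 442 nM

Going by the values given here, compound 1 gives the higher of the two numbers, but its only neighbour is close: the step of a 1.1-fold lower number from compound 1 to compound 2 (0.05 log units; within the scatter) stays within the scatter. Compound 3 `C=CCN1CCc2cc(OC)c(O)cc2C(c2ccccc2Cl)C1` differs from compound 1 by chloro in place of bromo on an aromatic carbon. Among the compounds with values here, no measured step bears on a halogen swap; the single step known concerns an oxygen substituent. Without a guide, compound 3 is expected to land near compound 1, and the step of a 1.2-fold higher number from compound 1 to compound 3 (0.08 log units; within the scatter) is expected to be small in this assay. The estimate for compound 3 is 600 nM, with a range from 250 nM to 1500 nM.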

Compound 3, inhibition constant: 264 nM
The estimate for compound 3 lay 2.3-fold (0.36 log units) above the measured number; low and high end bracket the measured number.
By their numbers in this assay, from the lowest: compounds 3, 2 and 1 (each within the scatter of the next).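

In this assay, the 2-bromophenyl to 2-chlorophenyl change gives a 1.9-fold lower number from compound 1 to compound 3 (0.28 log units; within the scatter). Going by these compounds alone, this is the first look at this position, and it shows that one halogen can replace the other on this aromatic carbon without a change beyond the scatter. It also shows that the oxygen substituent is not the only place on the core of compound 1 where a small edit leaves the number within the scatter.

Going by these compounds, whether fluoro, methyl or methoxy at this position, or plain hydrogen, would behave the same way remains open, as does the effect of the same swap on compound 2. The data shown offer no measured explanation for this result.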